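The compounds below may be only part of what the source reports. "The series", "measured", "known", "first", "only" and "open" are said of these compounds alone.

For the measured compounds named here, in an assay on HEK293 cells for antagonist activity at transient receptor potential cation channel subfamily V member 3 (Homo sapiens), read by FLIPR and calcium flux (on this read-out higher numbers stand for weaker inhibition and lower numbers for stronger inhibition), compound 1 `C[C@]1(O)C[C@](c2cccc(C(F)(F)F)c2)([C@H](O)c2ccccn2)C1` gives 1550 nM, the higher of the two numbers measured so far. Compound 2 `O[C@H](c1ccccn1)[C@]1(c2cccc(C(F)(F)F)c2)C[C@H](O)C1` gives 90 nM, and a 17-fold lower number from compound 1 to compound 2 (1.24 log units; beyond the scatter) came with a hydrogen in place of a methyl on a saturated ring carbon. Compound 3 `C[C@]1(O)C[C@@](c2cccc(C(F)(F)F)c2)([C@H](O)c2ccccn2)C1` keeps every atom and bond of compound 1: the two compounds have the same atoms and bonds and differ only in configuration as drawn: 2 of 3 stereo elements differ; a stereocentre at a saturated ring carbon is drawn S in compound 1 and R in compound 3; a stereocentre at a saturated ring carbon is drawn r in compound 1 and s in compound 3. Going by the values given here, the only measured step concerns a methyl, not configuration, so it does not bear on this change and no direction can be drawn from it. Compound 3 is therefore expected to stay close to the starting number, a 1.0-fold lower number from compound 1 to compound 3 (0.01 log units; within the scatter), with an estimate of 1500 nM, ranging from 300 nM to 8000 nM.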

Compound 3, antagonist equilibrium constant: 300 nM
Estimate against measurement, compound 3: 5.0-fold (0.70 log units) above; measured number inside the range.
By their numbers in this assay, from the lowest: compound 2; then compound 3; then compound 1.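

The methyl step left open whether configuration matters at this position, and it does: in this assay there is a 5.2-fold lower number from compound 1 to compound 3 (0.71 log units; beyond the scatter) with the methyl kept in place. The number moves with stereochemistry alone, because nothing else separates the pair, as the structures show: the fact that compounds 1 and 3 differ only in the configuration as drawn.

Two stereo elements change together, so the compounds shown do not tell which of them carries the step. Nor do they show how an amine in place of the hydroxyl on the saturated ring carbon would read in either configuration.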